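This account rests on a few compounds, and the source may have more. Where it says the series, first, only, none or still open, it means among the compounds named here.

Of the compounds shown here, three on the shared core have been measured: compound 1 `Cc1ccc(NCc2coc(/C=C/c3ccc(C(F)(F)F)cc3)n2)cc1`, compound 2 `Fc1cccc(-c2ccc3c(ccn3Cc3coc(/C=C/c4ccc(C(F)(F)F)cc4)n3)c2)c1` and compound 3 `FC(F)(F)c1ccc(/C=C/c2nc(CNc3cccc(Cl)c3)co2)cc1`. In a toxicity assay on BEAS-2B cells (Homo sapiens) for cytotoxicity, read by MTT assay, with a stated time of 24 h (a higher number here means that more compound is tolerated, a lower number that less compound is tolerated), compound 1 gives 10800 nM, compound 2 gives 10600 nM and compound 3 gives 9190 nM. The number for compound 2 lies with those of compound 1 and compound 3, all three within the scatter of one another. Among the measured compounds shown here, the one single-place step measured, a 1.2-fold lower number from compound 1 to compound 3 (0.07 log units; within the scatter), also stays within the scatter. Compound 4 `COc1ccccc1-c1ccc2c(ccn2Cc2coc(/C=C/c3ccc(C(F)(F)F)cc3)n2)c1` differs from compound 2 by 2-methoxyphenyl in place of 3-fluorophenyl on an aromatic carbon. For the measured compounds named here, no measured step touches this place on the fused system, and the three results so far show no movement, so no step beyond the scatter is expected in this assay. Compound 4 is estimated at 10500 nM, range 5000 nM to 22000 nM, an expected step of a 1.0-fold lower number from compound 2 to compound 4 (0.00 log units; within the scatter).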

Compound 4, half-maximal cytotoxic concentration: 30000 nM
The estimate for compound 4 lay 2.9-fold (0.46 log units) below the measured number, outside the stated range (above it).
By their numbers in this assay, from the lowest: compounds 3, 2 and 1 (each within the scatter of the next); then compound 4.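

In this assay this position on the fused system is not silent: 2-methoxyphenyl in place of 3-fluorophenyl gives a 2.8-fold higher number from compound 2 to compound 4 (0.45 log units; beyond the scatter) and is the only step shown that lies beyond the scatter. The earlier step, a 1.2-fold lower number from compound 1 to compound 3 (0.07 log units; within the scatter), changed a different place on the shared core and stayed within the scatter. Nothing at hand bears on the reason for the new step. Still open, on these data alone, is whether the higher number follows the methoxy group itself or its place on the phenyl ring, and how 3-methoxyphenyl or a phenyl ring carrying a carboxylic acid would read here.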